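From Methylsulfanyl to Methoxy: One Swap on Compound 2

The source may report more compounds than this note shows. Statements on the series, on what has been measured and on what is new or still open speak of the compounds shown alone.

Compound 1 `c1ccc(-c2nc3ccc[nH]c-3n2)cc1`: 8 mg/kg
Compound 2 `CSc1ccc(-c2nc3cc[nH]cc-3n2)cc1`: 4 mg/kg

Both numbers come from a functional assay on the whole organism with Canis familiaris (Canis lupus familiaris) as the target; on this read-out lower numbers stand for an effect already at smaller amounts and higher numbers for an effect only at larger amounts of compound. Compound 2 gives 4 mg/kg and compound 1 gives 8 mg/kg. These two values lie within the usual scatter of repeated measurements, so the data do not separate the compounds. The two structures also differ in more than one place, which means that their values say nothing about any single change.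

Compound 3 `COc1ccc(-c2nc3cc[nH]cc-3n2)cc1` keeps the core of compound 2 and carries methoxy in place of methylsulfanyl on an aromatic carbon. For the measured compounds named here, no measured pair of compounds shows this swap, so there is no direct precedent for its effect in this assay. The best available anchor is compound 2 at 4 mg/kg, and the range must stay wide with so little data. No shift in either direction beyond the scatter is expected, and the expected step is no change at the digits printed from compound 2 to compound 3 (within the scatter). For compound 3, the estimated value is 4 mg/kg, with an expected range from 1.5 mg/kg to 10 mg/kg.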

Compound 3, dose for half-maximal effect: 1.7 mg/kg
Beside the measured number, compound 3's estimate is 2.4-fold (0.37 log units) above it; the measured number falls inside the stated range.
By their numbers in this assay, from the lowest: compound 3; then compounds 2 and 1 (each within the scatter of the next).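

For the compounds shown here, this is the first step that can be read as a single change: in this assay, methoxy in place of methylsulfanyl on an aromatic carbon gives a 2.4-fold lower number from compound 2 to compound 3 (0.37 log units; beyond the scatter), a modest step but one beyond the scatter. It shows that this place, para to a group of 9 heavy atoms, responds to the choice of group, even though the two groups have the same counts of heavy atoms, hydrogen-bond donors and acceptors and differ only in having oxygen where the other has sulfur. Going by these compounds alone, the step shows only that the number moves, and no measurement here explains why it does so.

As far as these compounds go, it remains open whether the lower number extends to other groups on this carbon, such as a longer ether like ethoxy, an amine or a fluorine atom, or belongs to methoxy alone. Also open, from the compounds shown here alone, is how the core of compound 2 behaves with only hydrogen on this carbon, since compound 1 differs from compound 2 in more than one place and cannot answer that.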